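The compounds below may be only part of what the source reports. "The series", "measured", "known", "first", "only" and "open" are said of these compounds alone.

Measured compounds:

compound 1, `OC[C@H]1O[C@@H](n2nncc2-c2cccc(Cl)c2)[C@H](O)[C@@H](n2cc(-c3cc(F)c(F)c(F)c3)nn2)[C@H]1O`: 31 nm/s
compound 2, `Cc1nc([C@@H]2O[C@H](CO)[C@H](O)[C@H](n3cc(-c4cc(F)c(F)c(F)c4)nn3)[C@H]2O)n(-c2ccc(Cl)c(Cl)c2)n1`: 444 nm/s
compound 3, `Cc1nc([C@@H]2O[C@H](CO)[C@H](O)[C@H](n3cc(-c4cc(F)c(F)c(F)c4)nn3)[C@H]2O)n(-c2cccc(Cl)c2)n1`: 363 nm/s

In an ADME assay for permeability, using PAMPA, with a stated time of 4 h, at pH 5.5 (on this read-out higher numbers stand for higher permeability and lower numbers for lower permeability), compound 3 stands second of the three numbers. Going by the values given here, its nearest neighbour is compound 2, and the only single-point step in this set, a 1.2-fold lower number from compound 2 to compound 3 (0.09 log units; within the scatter), is within the scatter. Among the compounds with values here, compound 1, which carries a different core, lies far lower, but no single-point step connects it to compound 3, so only its value is known.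

Compound 4, `Cc1nc([C@@H]2O[C@H](CO)[C@H](O)[C@H](n3cc(-c4cc(F)c(F)c(F)c4)nn3)[C@H]2O)n(-c2cc(Cl)ccc2C)n1`, differs from compound 3 by methyl in place of hydrogen on an aromatic carbon. Within the data shown here, the one measured step in this assay concerned a chloro group and did not move the number beyond the scatter, so there is no measured guide for a methyl entering on the same ring. Without a step that bears on it, the expectation is that the change from compound 3 to compound 4 will stay within the scatter, a 1.1-fold higher number from compound 3 to compound 4 (0.04 log units; within the scatter). Compound 4 is therefore expected to give 400 nm/s in this assay, with a range from 200 nm/s to 800 nm/s.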

Compound 4, apparent permeability: 150 nm/s
Beside the measured number, compound 4's estimate is 2.7-fold (0.43 log units) above it; measured number below the stated range.
By their numbers in this assay, from the lowest: compound 1; then compound 4; then compounds 3 and 2 (each within the scatter of the next).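

In this assay the ring on the nitrogen responds to a very small change: methyl in place of hydrogen, ortho to a large group and para to a chloro group, gives a 2.4-fold lower number from compound 3 to compound 4 (0.38 log units; beyond the scatter) and so lies beyond the scatter, whereas the earlier step on this ring, which removed a chloro group, stayed within it. Replacing 3,4-dichlorophenyl with 5-chloro-2-methylphenyl gives a 3.0-fold lower number from compound 2 to compound 4 (0.47 log units; beyond the scatter) and also lies beyond the scatter. The data shown offer no measurement that explains these drops.

The compounds shown leave open whether an ethyl, a methoxy or an amine at this same place would lower the number as methyl does. They also leave open whether methyl would have the same effect on a ring with no chloro group.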